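The source may hold more compounds than are shown below. What is called first, only, known or untested is meant among the compounds shown, and "the series" means these compounds.

Compounds measured so far:

Compound 1, `O=c1c(O)c(-c2ccccc2)oc2cc(OCc3ccccc3Br)cc(O)c12`, in an ADME assay on Huh-5-2 cells (Homo sapiens) for cytotoxicity, read by WST assay, with a stated time of 3 days (a higher number here means that more compound is tolerated, a lower number that less compound is tolerated), gives > 100000 nM, which is a limit of the assay and not a number.
Compound 2, `N#Cc1cccc(COc2cc(O)c3c(=O)c(O)c(-c4ccccc4)oc3c2)c1`, in this assay gives 72000 nM.

Within the data shown here, compound 2 thus holds the only number in this assay; the one other value shown is a limit. Among the measured compounds shown here, the single measured step runs from compound 1 to compound 2, with 3-cyanophenyl in place of 2-bromophenyl on the saturated chain carbon bound to the ring oxygen, and reads an at least 1.3-fold lower number from compound 1 to compound 2 (0.14 log units; that floor lies within the scatter); its size rests on (the limit of > 100000 nM in this assay, at which 1 of the 2 values shown sits), so only a floor is known.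

Compound 3, `Cc1cccc(COc2cc(O)c3c(=O)c(O)c(-c4ccccc4)oc3c2)c1`, differs from compound 2 by methyl in place of cyano on an aromatic carbon. For the measured compounds named here, the only measured step bears on this change loosely, since it also alters the substituent of the benzyl ring, and its floor lies within the scatter. Compound 3 is therefore expected to show no step beyond the scatter in this assay, the expected step being a 1.2-fold higher number from compound 2 to compound 3 (0.07 log units; within the scatter). For compound 3 the estimate is 85000 nM, with a range from 35000 nM to 200000 nM.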

Compound 3, half-maximal cytotoxic concentration: 35000 nM
Compound 3: the middle estimate sits 2.4-fold (0.39 log units) above what was measured; the measured number falls inside the stated range.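

In this assay, the exchange of cyano for methyl on the aromatic carbon gives a 2.1-fold lower number from compound 2 to compound 3 (0.31 log units; beyond the scatter), and this is the first step shown with a number at both ends that lies beyond the scatter. It shows that the group at this place on the benzyl ring matters to the outcome: with the shared core and the rest of the benzyl ether unchanged, 3-methylbenzyl is tolerated at a lower concentration than 3-cyanobenzyl. The second new step, an at least 2.8-fold lower number from compound 1 to compound 3 (0.45 log units; beyond the scatter), also clears the scatter where the earlier floor did not, but its starting value is a limit of the assay and not a number, so only a floor is known: the limit of > 100000 nM in this assay, at which 1 of the 3 values shown sits.

The compounds shown leave open why methyl and cyano part here, and whether the difference tracks the group itself, since no other group at this place can be set beside them. A bromine at this same place would separate the effect of the group from that of its place on the ring, while an amine, a carboxylic acid or a methoxy group there would show how far the trend extends.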